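Propyl in place of furan-2-yl at the exocyclic alkene

The source may hold more compounds than are shown below. What is called first, only, known or untested is meant among the compounds shown, and "the series" means these compounds.

The shared core carries an acetylated glycosyl triazole; it varies only at the group on the double-bonded chain carbon bound to a double-bonded ring carbon. In a functional assay on MCF7 cells (Homo sapiens) for cytotoxicity, read by sulforhodamine B assay, with a stated time of 48 h (on this read-out lower numbers stand for stronger inhibition and higher numbers for weaker inhibition), compound 1 `CC(=O)OC[C@H]1O[C@@H](n2cc(CN3C(=O)/C(=C\c4ccc(C)cc4)c4ccccc43)nn2)[C@H](OC(C)=O)[C@@H](OC(C)=O)[C@@H]1OC(C)=O` gives only the limit > 100000 nM. Compound 2 `CC(=O)OC[C@H]1O[C@@H](n2cc(CN3C(=O)/C(=C\C=C\c4ccccc4)c4ccccc43)nn2)[C@H](OC(C)=O)[C@@H](OC(C)=O)[C@@H]1OC(C)=O` gives 34100 nM and compound 3 `CC(=O)OC[C@H]1O[C@@H](n2cc(CN3C(=O)/C(=C\c4ccco4)c4ccccc43)nn2)[C@H](OC(C)=O)[C@@H](OC(C)=O)[C@@H]1OC(C)=O` gives 38200 nM; the two lie within scatter of each other, with compound 3 the higher of the two numbers. The steps of an at least 2.9-fold lower number from compound 1 to compound 2 (0.46 log units; beyond the scatter) and an at least 2.6-fold lower number from compound 1 to compound 3 (0.41 log units; beyond the scatter) are at least modest, while a 1.1-fold higher number from compound 2 to compound 3 (0.05 log units; within the scatter) is within scatter.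

Compound 4 `CCC/C=C1\C(=O)N(Cc2cn([C@@H]3O[C@H](COC(C)=O)[C@@H](OC(C)=O)[C@H](OC(C)=O)[C@H]3OC(C)=O)nn2)c2ccccc21` differs from compound 3 by propyl in place of furan-2-yl on a double-bonded chain carbon bound to a double-bonded ring carbon. Within the data shown here, no measured step covers an aryl-to-alkyl exchange at this position; the known steps only move between aromatic or conjugated groups. A somewhat higher number is expected, with a fair chance of a limit: the estimate for compound 4 is 65000 nM, from 25000 nM to 170000 nM, meaning an expected step of a 1.7-fold higher number from compound 3 to compound 4 (0.23 log units; within the scatter).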

Compound 4, half-maximal inhibitory concentration: 25000 nM
Beside the measured number, compound 4's estimate is 2.6-fold (0.41 log units) above it, and the stated range covers the measured number.
By their numbers in this assay, from the lowest: compounds 4, 2 and 3 (each within the scatter of the next). At a limit, above all of these: compound 1.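

In this assay, propyl, with no ring, is not separated from the ring-bearing groups: a 1.5-fold lower number from compound 3 to compound 4 (0.18 log units; within the scatter) and a 1.4-fold lower number from compound 2 to compound 4 (0.13 log units; within the scatter), so a ring on the double-bonded chain carbon is not needed for numbers in this range. Compound 1 alone stands apart, with an at least 4.0-fold lower number from compound 1 to compound 4 (0.60 log units; beyond the scatter); this step is a bound, not a size: the limit of > 100000 nM in this assay, at which 1 of the 4 values shown sits.

As far as these compounds go, whether a longer chain or an amine at this position stays in the same range remains open. So does whether unsubstituted phenyl groups with this core behave like 4-methylphenyl or like furan-2-yl.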